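A few compounds are considered here, and "the series" means these few. Any claim that something is new, unique, unknown or untested is made for them only; others in the source may bear on it.

Measured compounds:
compound 1 `O=c1[nH]cc(S(=O)(=O)Nc2cccc(-c3cn(-c4ccccc4F)nn3)c2)c(=O)[nH]1` — 12500 nM
compound 2 `O=c1[nH]cc(S(=O)(=O)Nc2cccc(-c3cn(-c4cccc(Cl)c4)nn3)c2)c(=O)[nH]1` — 3410 nM
compound 3 `Cc1ccccc1-n1cc(-c2ccc(NS(=O)(=O)c3c[nH]c(=O)[nH]c3=O)cc2)nn1` — 7310 nM

In a functional assay on OVCAR-3 cells (Homo sapiens) for antiproliferative activity, read by MTT assay, with a stated time of 24 h (a higher number here means a weaker inhibitor, a lower number a stronger inhibitor), compound 3 gives the second highest of the three numbers. Its nearest neighbour is compound 1, whose value of 12500 nM lies within the scatter of that of compound 3, so the two cannot be ordered. Compound 2, at 3410 nM, sits beyond the scatter below compound 3.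

Compound 4 `O=c1[nH]cc(S(=O)(=O)Nc2ccc(-c3cn(-c4ccc(F)cc4)nn3)cc2)c(=O)[nH]1` has not yet been measured. It differs from compound 3 by 4-fluorophenyl in place of 2-methylphenyl on an aromatic nitrogen. Among the measured compounds shown here, the only measured step that also exchanges the group on that aromatic nitrogen is a 3.7-fold lower number from compound 1 to compound 2 (0.56 log units; beyond the scatter), although it runs between compounds whose remaining framework is not that of compound 3, so it bears on the new step only loosely. Taking it as the closest guide, a modest move to a lower number is expected for compound 4, of about a 1.8-fold lower number from compound 3 to compound 4 (0.26 log units; within the scatter). Compound 4 is therefore estimated at 4000 nM in this assay, with a range from 1500 nM to 12000 nM.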

Compound 4, half-maximal inhibitory concentration: > 20000 nM
Compound 4 gave a limit, no number (the forecaster's own chance of this, stated with the estimate: 3%); at least 5.0-fold (0.69 log units) between middle value and limit.
By their numbers in this assay, from the lowest: compound 2; then compounds 3 and 1 (each within the scatter of the next). At a limit, above all of these: compound 4.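

Compound 4 gives > 20000 nM in this assay, and this is a limit of the assay, not a number. Among the compounds shown here, with 4-fluorophenyl in place of 2-methylphenyl on the aromatic nitrogen, the result is an at least 2.7-fold higher number from compound 3 to compound 4 (0.43 log units; beyond the scatter), so on this framework the exchange moves the read-out towards weaker inhibition, whereas the only earlier exchange at this nitrogen went the other way: a 3.7-fold lower number from compound 1 to compound 2 (0.56 log units; beyond the scatter). The two groups count the same heavy atoms and neither has hydrogen-bond donors or acceptors, so that count does not separate them, and the aryl group on this nitrogen can shift the read-out in either direction.

As far as these compounds go, the full size of the step stays open because the value of compound 4 is only a limit: the limit of > 20000 nM in this assay, at which 1 of the 4 values shown sits. It is also open how an amine or a carboxylic acid on that phenyl ring, or an alkyl chain in its place, would read in this assay.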